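The source may report more compounds than this note shows. Statements on the series, on what has been measured and on what is new or still open speak of the compounds shown alone.

Compound 1 `COc1cc(C(F)(F)F)cc(C(F)(F)F)c1C(=O)NC1(c2ccccc2)CCCN(C2CCCC2)C1`: 270 nM
Compound 2 `COc1cc(C(F)(F)F)cc(C(F)(F)F)c1C(=O)NC1(c2ccccc2)CCCN(Cc2ccccc2)C1`: 6700 nM
Compound 3 `COc1cc(C(F)(F)F)cc(SC)c1C(=O)NC1(c2ccc(C)cc2)CCCN(C)C1`: 230 nM

In an assay on cells for inhibition of sodium- and chloride-dependent glycine transporter 1 (Homo sapiens) (on this read-out lower numbers stand for an effect already at smaller amounts and higher numbers for an effect only at larger amounts of compound), compound 3 gives the lowest of the three numbers, although compound 1 lies within the usual scatter of it; only compound 2 stands clearly apart. Compound 4 `COc1cc(C(F)(F)F)cc(SC)c1C(=O)NC1(c2ccncc2)CCCN(C)C1` differs from compound 3 in one place: pyridin-4-yl in place of 4-methylphenyl on a saturated ring carbon. Among the compounds with values here, the single measured step, a 25-fold higher number from compound 1 to compound 2 (1.39 log units; beyond the scatter), concerns the group on the ring nitrogen, a different part of the shared core, so it does not bear directly on this change. The expectation therefore rests on little. Compound 4 is expected to give 800 nM (range 250 nM to 3000 nM). That estimate would mean a 3.5-fold higher number from compound 3 to compound 4 (0.54 log units; beyond the scatter), a modest weakening that might still fall within the scatter.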

Compound 4, half-maximal effective concentration: 60 nM
For compound 4 the middle estimate is 13-fold (1.12 log units) above the measured one; measured number outside the range, below it.
By their numbers in this assay, from the lowest: compound 4; then compounds 3 and 1 (each within the scatter of the next); then compound 2.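

Swapping 4-methylphenyl for pyridin-4-yl on the saturated ring carbon gives a 3.8-fold lower number from compound 3 to compound 4 (0.58 log units; beyond the scatter) in this assay and is the first change shown at this position. The number falls rather than rises, so a nitrogen in this aromatic ring is tolerated here, at least with the other groups of compound 3 in place. No measurement shown explains this drop.

From the compounds shown here alone, the swap adds the ring nitrogen and removes the methyl group in one step, so their separate contributions stay unknown. Whether the location of that nitrogen matters is also open, as pyridin-3-yl does not appear among these compounds.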